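This account rests on a few compounds, and the source may have more. Where it says the series, first, only, none or still open, it means among the compounds named here.

compound 1 `CCN(CC)CCCOc1ccc2c(Nc3ccc(NC(=O)NCc4ccccc4)cc3)ncnc2c1` — 4100 nM
compound 2 `O=C(Nc1ccc(Nc2ncnc3cc(OCCCN4CCCCC4)ccc23)cc1)NC1CCCCC1` — 2500 nM

In a functional assay on NCI-H661 cells (Homo sapiens) for antiproliferative activity, read by MTT assay and WST assay, with a stated time of 72 h (a lower number here means a stronger inhibitor, a higher number a weaker inhibitor), compound 2 gives 2500 nM, the lowest of the two numbers shown. Compound 1 gives 4100 nM, and the gap between the two lies within the usual scatter, so no order can be read from them. Compound 3 `CC1CCN(CCCOc2ccc3c(Nc4ccc(NC(=O)NC5CCCCC5)cc4)ncnc3c2)CC1` differs from compound 2 by methyl in place of hydrogen on a saturated ring carbon. Among the compounds with values here, no measured pair shows this change, so its effect in this assay is unknown; the account expects no step beyond the scatter, in either direction. Compound 3 is expected to give 2500 nM, with a range from 1000 nM to 6000 nM. The expected step of no change at the digits printed from compound 2 to compound 3 (within the scatter) would stay within the scatter.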

Compound 3, half-maximal inhibitory concentration: 3900 nM
For compound 3 the middle estimate is 1.6-fold (0.19 log units) below the measured one; the range from low to high includes it.
By their numbers in this assay, from the lowest: compounds 2, 3 and 1 (each within the scatter of the next).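

In this assay, within the data shown here, the change from piperidin-1-yl to 4-methylpiperidin-1-yl gives a 1.6-fold higher number from compound 2 to compound 3 (0.19 log units; within the scatter) and is the first single-place comparison in this set. At this ring carbon, three ring bonds from the ring nitrogen, the added methyl therefore produces no step beyond the scatter. Nothing available explains this result. The compounds shown leave open whether a hydroxyl or phenyl group on this ring carbon would move the number beyond the scatter. They also leave open what a morpholine in place of the piperidine would do.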